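The source may report more compounds than this note shows. Statements on the series, on what has been measured and on what is new or still open speak of the compounds shown alone.

The measured compounds:

Compound 1, `N#Cc1cccc(-c2nc(Nc3cccnc3)sc2-n2ccnc2)c1`: 124 nM
Compound 2, `N#Cc1cccc(-c2nc(Nc3cnccn3)sc2-n2ccnc2)c1`: 11 nM

In an assay on CHO cells for displacement of a labelled ligand from adenosine receptor A3 (Homo sapiens) (on this read-out higher numbers stand for weaker inhibition and lower numbers for stronger inhibition), compound 2 gives 11 nM, the lower of the two numbers seen so far, while compound 1 gives 124 nM. Among the compounds with values here, the one measured step, an 11-fold lower number from compound 1 to compound 2 (1.05 log units; beyond the scatter), comes from swapping the group attached to the nitrogen, and it is the only guide available. Compound 3, `Cc1nccn1-c1sc(Nc2cnccn2)nc1-c1cccc(C#N)c1`, differs from compound 2 in another part of the molecule: methyl in place of hydrogen on an aromatic carbon. Within the data shown here, no measured step touches that ring, so the change from compound 1 to compound 2 does not bear directly on it, and the added methyl is a small group without donors or acceptors. For compound 3 the expectation is therefore a step of about a 1.4-fold higher number from compound 2 to compound 3 (0.13 log units; within the scatter), which is within the scatter. Compound 3 is thus expected to give roughly 15 nM in this assay, within a range from 4 nM to 60 nM.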

Compound 3, inhibition constant: 10 nM
Compound 3: the middle estimate sits 1.5-fold (0.18 log units) above what was measured; the range from low to high includes it.
By their numbers in this assay, from the lowest: compounds 3 and 2 (each within the scatter of the next); then compound 1.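

In this assay, the step of a 1.1-fold lower number from compound 2 to compound 3 (0.04 log units; within the scatter) shows that 2-methyl-1H-imidazol-1-yl and 1H-imidazol-1-yl cannot be told apart in this series, at least with pyrazin-2-yl on the nitrogen. Within the data shown here, this is the first measured change on this ring, and it shows that the aromatic carbon between two ring nitrogen atoms can carry a methyl without a step beyond the scatter. No available measurement offers an explanation for this result.

A single methyl says little about what else this carbon would accept, so an ethyl group, a longer chain, an amine or a carboxylic acid there could give a very different number. On these data alone, it also remains open whether methyl would read the same with pyridin-3-yl on the nitrogen, as in compound 1.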